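The source may hold more compounds than are shown below. What is called first, only, known or untested is meant among the compounds shown, and "the series" means these compounds.

Among the measured compounds shown here, compound 2 `Cc1ccc(C)c(Oc2ccc3nc(COc4cccc(C(=O)O)c4)n(C)c3c2)n1` holds the higher of the two numbers recorded in an ADME assay for permeability, using PAMPA, with a stated time of 4 h (on this read-out lower numbers stand for lower permeability and higher numbers for higher permeability), where compound 2 gives 11 10^-6 cm/s and compound 1 `Cc1cccc(Oc2ccc3nc(COc4cccc(C(=O)O)c4)n(C)c3c2)n1` gives 2.7 10^-6 cm/s; the single measured step, a 4.1-fold higher number from compound 1 to compound 2 (0.61 log units; beyond the scatter), is modest. Compound 3 `Cc1cc(Cl)cnc1Oc1ccc2nc(COc3cccc(C(=O)O)c3)n(C)c2c1` differs from compound 2 by 5-chloro-3-methylpyridin-2-yl in place of 3,6-dimethylpyridin-2-yl on an oxygen on an aromatic ring. For the measured compounds named here, no measured step covers this exchange, and the step from compound 1 to compound 2 concerns only the gain of a methyl, so it bears on it weakly. For compound 3 the expected step in this assay is a 1.1-fold higher number from compound 2 to compound 3 (0.04 log units; within the scatter), small or none beyond the scatter. Compound 3 is estimated at 12 10^-6 cm/s, with a range from 5 10^-6 cm/s to 25 10^-6 cm/s.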

Compound 3, apparent permeability: 13.7 10^-6 cm/s
For compound 3 the middle estimate is 1.1-fold (0.06 log units) below the measured one; the measured number falls inside the stated range.
By their numbers in this assay, from the lowest: compound 1; then compounds 2 and 3 (each within the scatter of the next).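

In this assay the exchange of 3,6-dimethylpyridin-2-yl for 5-chloro-3-methylpyridin-2-yl on the oxygen gives a 1.2-fold higher number from compound 2 to compound 3 (0.10 log units; within the scatter) and so shows that a chlorine-bearing ring can stand at this place with no change beyond the scatter. Set against 6-methylpyridin-2-yl, the same chlorine-bearing group gives a 5.1-fold higher number from compound 1 to compound 3 (0.71 log units; beyond the scatter) and stays a modest step. Nothing at hand accounts for either step. The compounds shown leave open how a nitrile or a methoxy group in place of the chlorine would read in this assay and whether an unsubstituted pyridin-2-yl would read with compound 1 or with the other two.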